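Moving the methoxy group from 3-methoxyphenyl to 4-methoxyphenyl

The source may report more compounds than this note shows. Statements on the series, on what has been measured and on what is new or still open speak of the compounds shown alone.

In a functional assay on FM3A cells (Mus musculus) for antiproliferative activity (on this read-out lower numbers stand for stronger inhibition and higher numbers for weaker inhibition), compound 1 (`COc1ccc(-c2cc(N)c(C(=O)c3cc(OC)c(OC)c(OC)c3)s2)cc1OC`) gives 72 nM while compound 2 (`COc1cc(C(=O)c2sc(-c3ccc([N+](=O)[O-])cc3)cc2N)cc(OC)c1OC`) gives 64 nM and compound 3 (`COc1cccc(-c2cc(N)c(C(=O)c3cc(OC)c(OC)c(OC)c3)s2)c1`) gives 36 nM on the same read-out. Compound 3 thus sits within the scatter of both others. Compound 4 (`COc1ccc(-c2cc(N)c(C(=O)c3cc(OC)c(OC)c(OC)c3)s2)cc1`) differs from compound 3 in one place (4-methoxyphenyl in place of 3-methoxyphenyl on an aromatic carbon): 4-methoxyphenyl in place of 3-methoxyphenyl on an aromatic carbon. Three measured steps on this same carbon bear on it (a 1.1-fold lower number from compound 1 to compound 2 (0.05 log units; within the scatter); a 2.0-fold lower number from compound 1 to compound 3 (0.30 log units; within the scatter); a 1.8-fold lower number from compound 2 to compound 3 (0.25 log units; within the scatter)) and all stay within the scatter. The expected step (a 1.3-fold higher number from compound 3 to compound 4 (0.10 log units; within the scatter)) is therefore no larger than the scatter and has no firm direction. Compound 4 is estimated at 45 nM with an expected range of 15 nM to 110 nM around it.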

Compound 4, half-maximal inhibitory concentration: 31 nM
Compound 4: middle estimate off by 1.5-fold (0.16 log units), on the high side, within the range that was stated.
By their numbers in this assay, from the lowest: compounds 4, 3, 2 and 1 (each within the scatter of the next, the first and the last beyond it).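

Shifting the methoxy group within the aryl group next to the ring sulfur changes little (a 1.2-fold lower number from compound 3 to compound 4 (0.06 log units; within the scatter)), so in this assay the 3-methoxyphenyl and 4-methoxyphenyl groups cannot be told apart. Going by these compounds alone, no step among the earlier compounds passed the scatter, but two modest steps now do: methoxy in place of nitro (a 2.1-fold lower number from compound 2 to compound 4 (0.31 log units; beyond the scatter)) and hydrogen in place of methoxy (a 2.3-fold lower number from compound 1 to compound 4 (0.37 log units; beyond the scatter)). Nothing available here accounts for these steps. From the compounds shown here alone, it remains open how an amine or a carboxylic acid in place of the methoxy group of compound 4 would read.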